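This account rests on a few compounds, and the source may have more. Where it says the series, first, only, none or still open, it means among the compounds named here.

Of the compounds shown here, three sharing one core have been tested in a functional assay on MCF7 cells (Homo sapiens) for antiproliferative activity, read by MTT assay, with a stated time of 72 h; on this read-out lower numbers stand for stronger inhibition and higher numbers for weaker inhibition. Compound 1 `CCc1ccccc1C(=O)Nc1ccc2nc(N3CCN(CC)CC3)cc(C)c2c1` gives 15800 nM, compound 2 `CCN1CCN(c2cc(C)c3cc(NC(=O)c4ccc5ccccc5n4)ccc3n2)CC1` gives 7060 nM, and compound 3 `CCN1CCN(c2cc(C)c3cc(NC(=O)c4ccc(Cl)c(Cl)c4)ccc3n2)CC1` gives 1380 nM. Compound 3 stands lowest of the three, with a 5.1-fold lower number from compound 2 to compound 3 (0.71 log units; beyond the scatter) and an 11-fold lower number from compound 1 to compound 3 (1.06 log units; beyond the scatter) both reaching beyond the scatter, so it is the most potent compound measured here.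

Compound 4 `CCN1CCN(c2cc(C)c3cc(NC(=O)c4ccccc4)ccc3n2)CC1` has not yet been measured. It differs from compound 3 in one place: phenyl in place of 3,4-dichlorophenyl on a carbonyl carbon. Within the data shown here, no measured step removes the two chlorines in just this way, so the bearing of the earlier steps is indirect. What the numbers do show is that the group on the carbonyl carbon matters strongly: an 11-fold lower number from compound 1 to compound 3 (1.06 log units; beyond the scatter) and a 5.1-fold lower number from compound 2 to compound 3 (0.71 log units; beyond the scatter) were both beyond the scatter, and the 3,4-dichlorophenyl gave the lowest value. Because an 11-fold lower number from compound 1 to compound 3 (1.06 log units; beyond the scatter) ties the lowest number of the set to the 3,4-dichlorophenyl group on compound 3, a move back toward a plain phenyl is expected to raise the number in this assay. The expected step is a 4.3-fold higher number from compound 3 to compound 4 (0.64 log units; beyond the scatter), a modest loss rather than a large one. Compound 4 is therefore estimated at 6000 nM, with a likely range from 2000 nM to 20000 nM.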

Compound 4, half-maximal inhibitory concentration: 14200 nM
The estimate for compound 4 lay 2.4-fold (0.37 log units) below the measured number, and the stated range covers the measured number.
By their numbers in this assay, from the lowest: compound 3; then compounds 2, 4 and 1 (each within the scatter of the next, the first and the last beyond it).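

In this assay, the two chlorines account for the standing of the 3,4-dichlorophenyl group on this carbonyl carbon: going to plain phenyl gives a 10-fold higher number from compound 3 to compound 4 (1.01 log units; beyond the scatter) as a large step, the first time they have been removed in isolation. Without them the remaining groups do not separate, with a 2.0-fold higher number from compound 2 to compound 4 (0.30 log units; within the scatter) for phenyl in place of quinolin-2-yl and a 1.1-fold lower number from compound 1 to compound 4 (0.05 log units; within the scatter) for hydrogen in place of ethyl on the aromatic ring, so among these four compounds only compound 3 stands apart. Nothing available here explains why the chlorines matter so much. As far as these compounds go, it remains open whether a single chlorine would keep the low number. Equally open, from the compounds shown here alone, is whether fluorine, bromine, methoxy or trifluoromethyl on the phenyl ring would do the same.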